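Swapping a Ring for a Chain on Compound 2

A few compounds are considered here, and "the series" means these few. Any claim that something is new, unique, unknown or untested is made for them only; others in the source may bear on it.

Of the compounds shown here, three have so far been measured in an assay on isolated protein for inhibition of Calpain-1 catalytic subunit (Sus scrofa); on this read-out lower numbers stand for stronger inhibition and higher numbers for weaker inhibition. Compound 1 `CC(C)C[C@@H](/C=N/N1CCOCC1)NC(=O)[C@@H](NS(=O)(=O)c1ccc(F)cc1)C(C)C` gives 790 nM. Compound 2 `CC(C)[C@H](NS(=O)(=O)c1ccc(F)cc1)C(=O)NC/C=N/N1CCOCC1` gives 6200 nM, and compound 3 `CC(C)C[C@@H](/C=N/NCCO)NC(=O)[C@@H](NS(=O)(=O)c1ccc(F)cc1)C(C)C` gives 190 nM. Compound 2 therefore carries the highest number of the three: its nearest neighbour is compound 1, reached through a 7.8-fold higher number from compound 1 to compound 2 (0.89 log units; beyond the scatter), and its furthest is compound 3. Compound 4 `CC(C)[C@H](NS(=O)(=O)c1ccc(F)cc1)C(=O)NC/C=N/NC(=O)CN(C)C` has not yet been measured; it differs from compound 2 in a single place: (((dimethylamino)methyl)carbonyl)amino in place of morpholin-4-yl on a double-bonded nitrogen.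

The measured step that bears most directly on this change is the one made on a double-bonded nitrogen of compound 1, where a 4.2-fold lower number from compound 1 to compound 3 (0.62 log units; beyond the scatter) followed the exchange of the ring for a short open chain carrying a hydrogen-bond donor. The group entering compound 4 likewise has no ring and a hydrogen-bond donor, but it is a different group, so the earlier step is a guide rather than a rule. A modest move toward a lower number is expected in this assay, and compound 4 is estimated at 2500 nM, with a likely range from 800 nM to 8000 nM. That expectation corresponds to a 2.5-fold lower number from compound 2 to compound 4 (0.39 log units; beyond the scatter).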

Compound 4, half-maximal inhibitory concentration: > 10000 nM
Compound 4: no number, only a limit; the forecaster's own chance of this, stated with the estimate: 5%; at least 4.0-fold (0.60 log units) between middle value and limit.
By their numbers in this assay, from the lowest: compound 3; then compound 1; then compound 2. At a limit, above all of these: compound 4.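

In this assay, on these data alone, compound 4 gives > 10000 nM, which is a limit of the assay and not a number, so its true position is unknown: the limit of > 10000 nM in this assay, at which 1 of the 4 values shown sits. The change can therefore be read only as a floor, an at least 1.6-fold higher number from compound 2 to compound 4 (0.20 log units; that floor lies within the scatter), which means that compound 4 could lie close to compound 2 or much further from it. Even so, this position no longer shows a single direction: on the core of compound 1, an open chain with a hydrogen-bond donor in place of morpholin-4-yl gave a 4.2-fold lower number from compound 1 to compound 3 (0.62 log units; beyond the scatter), whereas here losing the ring and gaining a donor produced no lower number.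

The compounds shown leave open whether this difference comes from the entering group itself or from the core, since (((dimethylamino)methyl)carbonyl)amino appears only on the core of compound 2 and (2-hydroxyethyl)amino only on that of compound 1. Also open, as far as these compounds go, is how a longer chain ending in a hydroxyl group, or a plain primary amine on such a chain, would read on the double-bonded nitrogen of either core.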